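A few compounds are considered here, and "the series" means these few. Any claim that something is new, unique, unknown or untested is made for them only; others in the source may bear on it.

Measured so far:
- compound 1 `O=c1c2ccccc2nc(CO[N+](=O)[O-])n1NS(=O)(=O)c1ccccc1`: 2.4%
- compound 2 `CC(=O)Nc1ccc(S(=O)(=O)Nn2c(C)nc3ccccc3c2=O)cc1`: 20.8%

In a functional assay on the whole organism (strain Sprague-Dawley) for inhibition, with Rattus norvegicus as the target, read by paw edema, with stated times of 30 min and 1 h, at a dose of 80 mg/kg by the oral route (on this read-out higher numbers stand for more inhibition at the one dose given (going by the name of the read-out) and lower numbers for less inhibition), compound 2 gives 20.8%, the highest of the two numbers; compound 1 gives 2.4%, a gap beyond the scatter. Compound 1 differs from compound 2 in more than one place, so its low number alone does not show which part matters. Compound 3 `CC(=O)Nc1ccc(S(=O)(=O)Nn2c(CO[N+](=O)[O-])nc3ccccc3c2=O)cc1` carries the change (nitrooxy in place of hydrogen on a saturated chain carbon bound to an aromatic carbon). Among the compounds with values here, no step between measured compounds covers this change. A small drop is expected for compound 3, a number 7.8 percentage points lower from compound 2 to compound 3 (within the scatter), possibly not beyond the scatter. The estimate for compound 3 is 13%, within 0% to 30%.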

Compound 3, a percentage reported as inhibition, in the whole organism at one dose (the size of the read-out at that dose, not a potency): 15.2%
Estimate against measurement, compound 3: 2.2 percentage points below, and the stated range covers the measured number.
By their numbers in this assay, from the lowest: compound 1; then compounds 3 and 2 (each within the scatter of the next).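

In this assay, methyl to (nitrooxy)methyl on the saturated chain carbon bound to an aromatic carbon gives a number 5.6 percentage points lower from compound 2 to compound 3 (within the scatter), so this change has no effect that can be told from the scatter. With nitrooxy held constant, acetamido in place of hydrogen on an aromatic carbon gives a number 12.8 percentage points higher from compound 1 to compound 3 (beyond the scatter), which ties the low number of compound 1 to the absent acetamido group. Nothing available explains either step. Open, as far as these compounds go, is whether an amine, a carboxylic acid or a longer chain at this carbon would shift the number, and whether acetamido matters equally when methyl replaces (nitrooxy)methyl.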